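The source may hold more compounds than are shown below. What is called first, only, known or untested is meant among the compounds shown, and "the series" means these compounds.

Compound 1 `CCCC(O)CC(=O)O[C@H](CC=C(C)C)C1=CC(=O)c2c(O)ccc(O)c2C1=O` gives > 100000 nM.
Compound 2 `CC(C)=CC[C@@H](OC(=O)c1ccco1)C1=CC(=O)c2c(O)ccc(O)c2C1=O` gives > 100000 nM.

In a functional assay on DU-145 cells (Homo sapiens) for cytotoxicity, read by MTT assay (a higher number here means a weaker inhibitor, a lower number a stronger inhibitor), compound 2 gives > 100000 nM, which is a limit of the assay and not a number. Compound 1 likewise reaches only a limit in this assay, > 100000 nM. For the measured compounds named here, the one measured step, a step that the two limits leave unreadable from compound 1 to compound 2, is thus unreadable, as the limit of > 100000 nM in this assay, at which 2 of the 2 values shown sit, shows. Compound 3 `CC(C)=CC[C@@H](OC(=O)CC(C)(O)C(C)C)C1=CC(=O)c2c(O)ccc(O)c2C1=O` differs from compound 2 by 2-hydroxy-2,3-dimethylbutyl in place of furan-2-yl on a carbonyl carbon. Going by the values given here, no measured step bears on this change, so compound 3 is expected to show a step of a number no higher from compound 2 to compound 3 (the limit leaves the size open) of no readable size. The estimated value of compound 3 is 100000 nM, within 30000 nM to 300000 nM, most probably again a limit.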

Compound 3, half-maximal inhibitory concentration: 16900 nM
Estimate against measurement, compound 3: 5.9-fold (0.77 log units) above, and the stated range ends above it.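

In this assay, 2-hydroxy-2,3-dimethylbutyl in place of furan-2-yl on a carbonyl carbon gives an at least 5.9-fold lower number from compound 2 to compound 3 (0.77 log units; beyond the scatter). 1-hydroxy-1,2-dimethylpropyl in place of 1-hydroxybutyl on a saturated chain carbon bound to a carbonyl carbon gives an at least 5.9-fold lower number from compound 1 to compound 3 (0.77 log units; beyond the scatter), so a hydroxyl on the chain is not enough by itself, since compound 1 also carries one. Both steps give only a minimum size, because each starts from a limit: the limit of > 100000 nM in this assay, at which 2 of the 3 values shown sit.

Going by these compounds, it remains open whether the hydroxyl of compound 3 is needed or the branched chain suffices. An amine in place of that hydroxyl, or the same chain without it, would address this.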